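Compound 1 and its mirror image

This account rests on a few compounds, and the source may have more. Where it says the series, first, only, none or still open, it means among the compounds named here.

Compound 1 `CCOC(=O)[C@@]1(C(=O)Nc2ccccc2)C[C@@H]1c1cc(OC)c(OC)c(OC)c1` gives little sign of activity in a functional assay on SW480 cells (Homo sapiens) for cytotoxicity, read by MTT assay, with a stated time of 48 h; a lower number here means a stronger inhibitor, a higher number a weaker inhibitor. In this assay compound 1 gives > 100000 nM, which is a limit of the assay and not a number. Its true position is therefore unknown, and any step away from it can only be estimated loosely. A related compound, compound 2 `CCOC(=O)C1(C(=O)NCc2ccc(F)cc2)CC1c1cc(OC)c(OC)c(OC)c1`, gives 34100 nM; 28400 nM (2 entries), two entries that agree well.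

Compound 4 `CCOC(=O)[C@]1(C(=O)Nc2ccccc2)C[C@H]1c1cc(OC)c(OC)c(OC)c1` is the partner of compound 1: the two compounds have the same atoms and bonds and differ only in configuration as drawn: 2 of 2 stereo elements differ (all stereocentres are inverted: mirror images); a stereocentre at a saturated ring carbon is drawn S in compound 1 and R in compound 4; a stereocentre at a saturated ring carbon is drawn R in compound 1 and S in compound 4. Nothing enters or leaves, and each stereocentre at a saturated ring carbon is simply inverted, so the two are mirror images.

The closest guide is compound 3 `CCOC(=O)C1(C(=O)Nc2ccccc2)CC1c1cc(OC)c(OC)c(OC)c1`, and its link to compound 1 is the fact that one of compounds 1 and 3 is drawn with a defined configuration and the other without, at the place where they differ. Compound 3 gives 49000 nM; > 100000 nM (2 entries), where only one entry is a single number. That single number leaves room for a modest gain in inhibition for compound 4, though the evidence is thin and compound 4 may also end up reported only as a limit. In this assay the expected change is an at least 1.6-fold lower number from compound 1 to compound 4 (0.22 log units; that floor lies within the scatter), a small move towards stronger inhibition. For compound 4 the estimated value is 60000 nM, with an expected range from 25000 nM to 150000 nM.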

Compound 4, half-maximal inhibitory concentration: > 100000 nM
Compound 4 was reported as a limit; the forecaster's own chance of this, stated with the estimate: 45%; middle value at least 1.6-fold (0.22 log units) away from the limit.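

Among the compounds shown here, compound 1 and compound 4 are both reported in this assay only as a limit of the assay, not as a number, and no step between these mirror images can be read. The compounds shown leave open whether the two mirror images differ at all, and how each relates to compound 3, which is drawn without defined configuration.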